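The compounds below may be only part of what the source reports. "The series", "measured", "known", "first", "only" and "open" are said of these compounds alone.

Measured compounds in an assay on HEK293 cells for agonist activity at transient receptor potential cation channel subfamily M member 8 (Homo sapiens), read by fluorescence and calcium flux, with a stated time of 15 min; on this read-out lower numbers stand for an effect already at smaller amounts and higher numbers for an effect only at larger amounts of compound: compound 1 `CCN(Cc1cccs1)C(=O)COc1ccc(C)cc1` gives 8 nM; compound 2 `CCN(Cc1cccs1)C(=O)COc1ccc(F)cc1` gives 422 nM; compound 3 `CCc1ccc(OCC(=O)N(CC)Cc2cccs2)cc1` gives 67 nM.

Compound 3 stands second highest of the three numbers in this assay, set apart by a 6.3-fold lower number from compound 2 to compound 3 (0.80 log units; beyond the scatter) and by an 8.4-fold higher number from compound 1 to compound 3 (0.92 log units; beyond the scatter). Compound 4 `CCN(Cc1cccs1)C(=O)COc1ccccc1` differs from compound 3 by hydrogen in place of ethyl on an aromatic carbon, on an aromatic carbon of a six-membered aromatic ring of carbon only, para to a large group. For the measured compounds named here, two measured steps bear on this change at the same position: an 8.4-fold higher number from compound 1 to compound 3 (0.92 log units; beyond the scatter) and a 53-fold higher number from compound 1 to compound 2 (1.72 log units; beyond the scatter), both moving away from methyl and both raising the number. With no group left at that position, a further modest rise is expected, estimated as a 3.7-fold higher number from compound 3 to compound 4 (0.57 log units; beyond the scatter). Compound 4 is therefore expected to give about 250 nM in this assay, within the range 60 nM to 1000 nM.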

Compound 4, half-maximal effective concentration: 1400 nM
Compound 4: middle estimate off by 5.6-fold (0.75 log units), on the low side; measured number outside the range, above it.
By their numbers in this assay, from the lowest: compound 1; then compound 3; then compound 2; then compound 4.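

The position turns out to need a group: taking ethyl away for hydrogen is a large step (a 21-fold higher number from compound 3 to compound 4 (1.32 log units; beyond the scatter)), and hydrogen in place of methyl is larger still (a 180-fold higher number from compound 1 to compound 4 (2.24 log units; beyond the scatter)). Even fluoro keeps the number lower than hydrogen does (a 3.3-fold higher number from compound 2 to compound 4 (0.52 log units; beyond the scatter)), so all three groups shown at this place, para to a large group, give lower numbers than hydrogen. No measurement at hand explains this order. The compounds shown leave open whether methoxy, chloro or a longer chain such as propyl would stay near compound 1 or fall back towards compound 3.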